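The source may hold more compounds than are shown below. What is called first, only, known or untested is meant among the compounds shown, and "the series" means these compounds.

Measured compounds:
compound 1 `Cc1ccccc1C(Oc1cc(OCc2ccccc2)ccc1C#N)C(=O)O`, 49 nM
compound 2 `Cc1ccccc1C(Oc1cc(OCc2ccnc(F)c2)ccc1C#N)C(=O)O`, 23 nM
compound 3 `N#Cc1ccc(OCc2ccc3ncoc3c2)cc1OC(C(=O)O)c1ccccc1Cl`, 9 nM

These three compounds were tested in an assay on A10 cells for antagonist activity at Endothelin-1 receptor (Rattus norvegicus); a higher number here means a weaker inhibitor, a lower number a stronger inhibitor. Compound 3 gives the lowest number of the three: compound 2 stands nearest to it, and compound 1 furthest away, both gaps being beyond the usual scatter of repeated measurements. Compound 4 `Cc1ccccc1C(Oc1cc(OCc2ccc3ncoc3c2)ccc1C#N)C(=O)O` has not yet been measured. It differs from compound 3 in one place: methyl in place of chloro on an aromatic carbon, which at one bond further out reads as 2-chlorophenyl to 2-methylphenyl.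

Going by the values given here, no measured step isolates this exchange. Among the compounds with values here, the only single-point step recorded, a 2.1-fold lower number from compound 1 to compound 2 (0.33 log units; beyond the scatter), concerns a different part of the molecule, the group on the saturated chain carbon bound to an oxygen on the aromatic ring, and it was modest. Compound 1 and compound 2 both carry the 2-methylphenyl group that compound 4 would carry, but each differs from compound 3 in the other position as well, so their values cannot be read as a clean measure of chloro against methyl. On this basis the expected step is small: a 1.7-fold higher number from compound 3 to compound 4 (0.22 log units; within the scatter), likely within the scatter. Compound 4 is therefore estimated at 15 nM in this assay, with a range from 6 nM to 40 nM.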

Compound 4, half-maximal inhibitory concentration: 6 nM
Estimate against measurement, compound 4: 2.5-fold (0.40 log units) above, within the range that was stated.
By their numbers in this assay, from the lowest: compounds 4 and 3 (each within the scatter of the next); then compound 2; then compound 1.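

In this assay the exchange of 2-chlorophenyl to 2-methylphenyl now has a direct measure with everything else held fixed: a 1.5-fold lower number from compound 3 to compound 4 (0.18 log units; within the scatter) lies within the scatter, so on this aromatic carbon chloro and methyl cannot be told apart. With 2-methylphenyl kept in place, the other variable group can also be compared, and a 3.8-fold lower number from compound 2 to compound 4 (0.58 log units; beyond the scatter) and an 8.2-fold lower number from compound 1 to compound 4 (0.91 log units; beyond the scatter) are both beyond the scatter and both larger than a 2.1-fold lower number from compound 1 to compound 2 (0.33 log units; beyond the scatter) for the change from phenyl to 2-fluoropyridin-4-yl, so among these three groups the 1,3-benzoxazol-6-yl group gives the lowest number. Nothing measured here explains either result.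

On these data alone, whether a methoxy group, a fluoro or a plain hydrogen on this aromatic carbon would also match chloro and methyl remains open. As far as these compounds go, it is equally open whether chloro and methyl would still match with phenyl or 2-fluoropyridin-4-yl in place of the 1,3-benzoxazol-6-yl group, since the direct comparison exists for that one group alone.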